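Piperidine for Morpholine on a Thiosemicarbazone Core

The compounds below may be only part of what the source reports. "The series", "measured", "known", "first", "only" and "open" are said of these compounds alone.

Measured compounds:
compound 1 `N/C(=N\NC(=S)N1CCOCC1)c1ccccn1` gives 82.8%
compound 2 `Cc1ccnc(/C(N)=N/NC(=S)N2CCOCC2)c1` gives 45.2%
compound 3 `Cc1cccc(/C(N)=N/NC(=S)N2CCSCC2)n1` gives 85.3%

In a functional assay on HeLa cells (Homo sapiens) for cytotoxicity, read by MTT assay, with a stated time of 72 h, tested at 30 uM (a lower number here means less inhibition of growth, a higher number more inhibition of growth at the concentration tested), compound 1 gives 82.8%. Among the three numbers, compound 1 lies near compound 3, the gap being within the scatter, and far from compound 2, the gap being beyond the scatter. Going by the values given here, the only step between compounds that differ in one place runs a number 37.6 percentage points lower from compound 1 to compound 2 (beyond the scatter), a change of methyl in place of hydrogen on an aromatic carbon; it says nothing about the ring on the thiocarbonyl carbon. Compound 3 carries both a methyl and a different ring, so its value alone cannot be set against compound 1 as a single step.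

Compound 4 `N/C(=N\NC(=S)N1CCCCC1)c1ccccn1` differs from compound 1 in one place: piperidin-1-yl in place of morpholin-4-yl on a thiocarbonyl carbon. Among the compounds with values here, no measured step bears on this change, so the expectation rests on compound 1 itself. With nothing to point to a shift, compound 4 is expected to stay near compound 1, the estimated step being a number 2.8 percentage points lower from compound 1 to compound 4 (within the scatter), that is, none beyond the scatter. For compound 4 the estimate in this assay is 80%, with a range from 55% to 95%.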

Compound 4, percent growth inhibition at one concentration: 76.9%
Compound 4: the middle estimate sits 3.1 percentage points above what was measured; the measured number falls inside the stated range.
By their numbers in this assay, from the lowest: compound 2; then compounds 4, 1 and 3 (each within the scatter of the next).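

In this assay, going by these compounds alone, the replacement of morpholin-4-yl by piperidin-1-yl on a thiocarbonyl carbon gives the first reading of a change at this position alone, and the step is a number 5.9 percentage points lower from compound 1 to compound 4 (within the scatter). Within the data shown here, the hydrogen-bond acceptor counted on morpholin-4-yl and absent from piperidin-1-yl can therefore go without a shift beyond the scatter in this read-out at the one concentration tested, which sets this change apart from the only earlier single step, a number 37.6 percentage points lower from compound 1 to compound 2 (beyond the scatter), made on an aromatic carbon. Nothing at hand explains why the two rings read alike, and no independent measurement bears on this result.

What the compounds shown leave open is whether this tolerance extends to other groups on the thiocarbonyl carbon, such as piperazin-1-yl with its second ring nitrogen, a small open-chain dimethylamino group or a ring carrying a carboxylic acid. They also leave open whether piperidin-1-yl would read the same on a core bearing a methyl on the aromatic ring, as in compound 2, where the number already stands far from that of compound 1.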